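The source may report more compounds than this note shows. Statements on the series, on what has been measured and on what is new or still open speak of the compounds shown alone.

Among the measured compounds shown here, compound 3 `CCOc1cc(NC(=O)C2(NC(=O)c3ccc4c(C5CCCC5)c(-c5ncc(Cl)cn5)n(C)c4c3)CCC2)ccc1/C=C/C(=O)OCCOc1ccccc1` gives 16.5 h in an ADME assay (liver) for pharmacokinetics, with Liver microsome (Rattus norvegicus) as the target, using microsomes (on this read-out higher numbers stand for a longer-lived compound and lower numbers for a shorter-lived compound), the highest of the three numbers known. Compound 2 `CCOc1cc(NC(=O)C2(NC(=O)c3ccc4c(C5CCCC5)c(-c5ncc(Cl)cn5)n(C)c4c3)CCC2)ccc1/C=C/C(=O)OCc1ccccc1` gives 2.17 h in this assay, and compound 1 `CCOc1cc(NC(=O)C2(NC(=O)c3ccc4c(C5CCCC5)c(-c5ncc(Cl)cn5)n(C)c4c3)CCC2)ccc1/C=C/C(=O)OCC(Cl)(Cl)Cl` gives 0.233 h. Compound 4 `CCOc1cc(NC(=O)C2(NC(=O)c3ccc4c(C5CCCC5)c(-c5ncc(Cl)cn5)n(C)c4c3)CCC2)ccc1/C=C/C(=O)OCC(=O)N1CCCC1` differs from compound 3 by (pyrrolidin-1-yl)carbonyl in place of phenoxymethyl on a saturated chain carbon bound to an oxygen next to a carbonyl group. Every measured step sits at this same place and each was clearly beyond the scatter: a 9.3-fold higher number from compound 1 to compound 2 (0.97 log units; beyond the scatter), a 71-fold higher number from compound 1 to compound 3 (1.85 log units; beyond the scatter) and a 7.6-fold higher number from compound 2 to compound 3 (0.88 log units; beyond the scatter). The read-out is therefore sensitive to what stands here, yet none of those steps tests the group now entering, so the direction rests on little. With compound 3 already at the top of the set, a step downward is expected, a 5.5-fold lower number from compound 3 to compound 4 (0.74 log units; beyond the scatter). Compound 4 is thus estimated at 3 h, within a range from 0.5 h to 15 h.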

Compound 4, half-life: 1.47 h
Estimate against measurement, compound 4: 2.0-fold (0.31 log units) above; low and high end bracket the measured number.
By their numbers in this assay, from the lowest: compound 1; then compounds 4 and 2 (each within the scatter of the next); then compound 3.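

In this assay, among the compounds shown here, (pyrrolidin-1-yl)carbonyl, the first group at this place to carry nitrogen, does not hold the level reached with phenoxymethyl (an 11-fold lower number from compound 3 to compound 4 (1.05 log units; beyond the scatter)). It stands level with phenyl (a 1.5-fold lower number from compound 2 to compound 4 (0.17 log units; within the scatter)) and remains clear of trichloromethyl (a 6.3-fold higher number from compound 1 to compound 4 (0.80 log units; beyond the scatter)), so among these compounds a ring in the group does not by itself reach the level of compound 3. Nothing measured here explains these differences.

Going by these compounds, whether a carboxylic acid or an open-chain diethylaminocarbonyl at this place would stand nearer compound 3 or compound 1 remains open. So does the effect of a longer chain carrying the (pyrrolidin-1-yl)carbonyl.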